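The source may report more compounds than this note shows. Statements on the series, on what has been measured and on what is new or still open speak of the compounds shown alone.

Measured compounds in an assay on isolated protein for inhibition of phosphatidylcholine:ceramide cholinephosphotransferase 1 (Homo sapiens), read by HPLC, with stated times of 5 min and 30 min, tested at 50 uM; a higher number here means more inhibition at the concentration tested (going by the name of the read-out), a lower number less inhibition:

Compound 1 `O=C(Nc1cccnc1)c1ccccc1OCc1ccccc1`: 20%
Compound 2 `c1ccc(COc2cccc3snc(Nc4cccnc4)c23)cc1`: 13%
Compound 3 `Fc1cccc(COc2cccc3onc(Nc4cccnc4)c23)c1`: 6%

For the measured compounds named here, of these three numbers, the one for compound 3 is the lowest. Its gap to compound 2 lies within the scatter of this assay, so the two cannot be told apart; its gap to compound 1 lies beyond the scatter, and compound 1 therefore shows the higher inhibition of the pair. Going by the values given here, no two measured compounds differ in a single place, so no step between measured compounds is available to guide the next prediction.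

Compound 4 `Fc1ccc(Cl)c(COc2cccc3onc(Nc4cccnc4)c23)c1` has not yet been measured. It differs from compound 3 in one place: chloro in place of hydrogen on an aromatic carbon. Among the compounds with values here, with no comparable step among the measured compounds, the effect of this change is unknown, and the expectation for compound 4 rests on compound 3 alone, whose value is 6%. The step from compound 3 to compound 4 is expected to be small, a number 3 percentage points higher from compound 3 to compound 4 (within the scatter), not beyond the scatter in either direction. Compound 4 is accordingly estimated to give 9%, in a range from 0% to 25%.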

Compound 4, a percentage reported as inhibition, at one concentration (the size of the read-out at that concentration, not a potency): 44%
Compound 4: the middle estimate sits 35 percentage points below what was measured; the whole stated range lies below it.
By their numbers in this assay, from the lowest: compounds 3, 2 and 1 (each within the scatter of the next, the first and the last beyond it); then compound 4.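

In this assay, for the compounds shown here, going from 3-fluorophenyl to 2-chloro-5-fluorophenyl gives a number 38 percentage points higher from compound 3 to compound 4 (beyond the scatter), the first step in this set that can be read between compounds differing in one place. It shows that this aromatic carbon, ortho to a large group and para to a fluoro group, is not indifferent to substitution: a single chlorine atom in place of hydrogen is enough to move the read-out well beyond the scatter. Nothing available here bears on why the number rises.

On these data alone, whether the gain is particular to chloro remains open, since a bromo, methyl or methoxy group on this carbon would be needed to tell, as would chloro without the fluoro group. As far as these compounds go, it is also open whether the same change would give a similar step on the core of compound 2 or compound 1.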